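A few compounds are considered here, and "the series" means these few. Any claim that something is new, unique, unknown or untested is made for them only; others in the source may bear on it.

Measured compounds:
compound 1 `COC(=O)[C@@]1(C)CCC=C2[C@@H]1CC[C@@H](C)[C@]2(C)Cc1c(C)[nH]c2c(C)cccc12` — 14000 nM
compound 2 `COC(=O)[C@@]1(C)CCC=C2[C@@H]1CC[C@@H](C)[C@]2(C)Cc1c(C)[nH]c2c(Cl)cccc12` — 17000 nM
compound 3 `COC(=O)[C@@]1(C)CC[C@@H]2C3=C1CC[C@@H](C)[C@]3(C)C[C@@H]1c3ccccc3N[C@H]21` — 19000 nM

All three numbers come from a functional assay on HeLa cells (Homo sapiens) for inhibition, read by sulforhodamine B assay, with a stated time of 48 h; on this read-out higher numbers stand for weaker inhibition of growth and lower numbers for stronger inhibition of growth. Compound 3 sits alongside compound 2 and compound 1: both gaps to it are within the scatter, so the three measured compounds cannot be told apart on this read-out.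

Compound 4 `COC(=O)[C@@]1(C)CC[C@@H]2C3=C1CC[C@@H](C)[C@]3(C)C[C@@H]1c3cc(Cl)ccc3N[C@H]21` differs from compound 3 by chloro in place of hydrogen on an aromatic carbon. Among the compounds with values here, no measured pair carries exactly this change. Within the data shown here, the only step that bears on it is the aromatic chloro step on the other core, a 1.2-fold higher number from compound 1 to compound 2 (0.08 log units; within the scatter), which did not move the number beyond the scatter. That step swaps chloro for methyl rather than for hydrogen, and it sits on a different ring system, so it is a loose guide only.

On that basis no step beyond the scatter is expected from compound 3 to compound 4, no change at the digits printed from compound 3 to compound 4 (within the scatter). Compound 4 is therefore estimated at 19000 nM, with a range from 9000 nM to 40000 nM.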

Compound 4, concentration for 50% growth inhibition: 23000 nM
Estimate against measurement, compound 4: 1.2-fold (0.08 log units) below; the measured number falls inside the stated range.
By their numbers in this assay, from the lowest: compounds 1, 2, 3 and 4 (each within the scatter of the next).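

In this assay, chloro in place of hydrogen, on the aromatic carbon that is meta to a fused ring and para to a fused ring, gives a 1.2-fold higher number from compound 3 to compound 4 (0.08 log units; within the scatter), so this change at this position on the core of compound 3 does not separate the two compounds on this read-out. The earlier chloro step, a 1.2-fold higher number from compound 1 to compound 2 (0.08 log units; within the scatter), replaced methyl on a different core, whereas this pair reads chloro directly against hydrogen on the core of compound 3. No supporting data bear on why the step stays this small.

Open, from the compounds shown here alone, is whether an amine, a carboxylic acid or a methoxy group on this same aromatic carbon would also stay within the scatter. Also open, going by these compounds, is whether chloro on the other aromatic carbons of this ring would behave like compound 4.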